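The compounds below may be only part of what the source reports. "The series", "measured", "known", "first", "only" and "open" are said of these compounds alone.

Compound 1 (`Clc1ccc(Nc2nc(-c3cccnn3)c(Cl)s2)nc1`): < 10000 nM
Compound 2 (`Clc1ccc(Nc2nc(-c3cnccn3)cs2)nc1`): < 10000 nM

In a physicochemical assay for solubility, in phosphate buffer, with a stated time of 2 h, at pH 7.4 (a higher number here means a more soluble compound, a lower number a less soluble compound), compound 2 gives < 10000 nM as a limit of the assay and not a number. Compound 1 gives < 10000 nM and that too is a limit. The two compounds therefore share one reading (the limit of < 10000 nM in this assay, at which 2 of the 2 values shown sit) and neither can be ranked against the other.

Compound 3 (`Clc1ccc(Nc2nc(-c3cnccn3)c(Cl)s2)nc1`) differs from compound 2 by chloro in place of hydrogen on an aromatic carbon, next to the ring sulfur and next to the ring atom that bears a pyrazin-2-yl group. For the measured compounds named here, no measured step between two compounds is available, so only a small change in this assay is expected, downward if anything, and perhaps none beyond the scatter. The expected move is a step that the limit leaves unreadable from compound 2 to compound 3 on this estimate. A limit rather than a number is again the likelier report for compound 3. Compound 3 is estimated at 5000 nM (expected range 1000 nM to 10000 nM).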

Compound 3, solubility: < 10000 nM
Compound 3 ended at the assay's limit; the forecaster's own chance of this, stated with the estimate: 85%; the middle value does not contradict the limit.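

No step can be read from compound 2 to compound 3, or from compound 1 to compound 3, in this assay, because all three compounds share one reading: the limit of < 10000 nM in this assay, at which 3 of the 3 values shown sit.

The compounds shown leave open how far apart these three lie, and whether chloro in place of hydrogen or pyrazin-2-yl in place of pyridazin-3-yl makes any difference.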